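The source may hold more compounds than are shown below. What is called first, only, known or untested is meant among the compounds shown, and "the series" means these compounds.

In a functional assay on MC-38 cells (Mus musculus) for antiproliferative activity, read by CCK-8 assay, with a stated time of 48 h (a higher number here means a weaker inhibitor, a lower number a stronger inhibitor), compound 1 `O=C(CCCCOc1cccc(-c2nnc(-c3ccccc3)s2)c1)NO` gives 7100 nM and compound 2 `O=C(CCCCCCOc1cccc(-c2nnc(-c3ccccc3)s2)c1)NO` gives 2400 nM as the lower of the two numbers. Among the compounds with values here, the single measured step (a 3.0-fold lower number from compound 1 to compound 2 (0.47 log units; beyond the scatter)) is modest but beyond the scatter, and it lies in the chain. Compound 3 `O=C(CCCCCCOc1cccc(-c2nnc(-c3ccccc3Cl)s2)c1)NO` keeps the chain of compound 2 and changes phenyl to 2-chlorophenyl (chloro in place of hydrogen on an aromatic carbon), with chloro in place of hydrogen on an aromatic carbon. Within the data shown here, no measured step touches that ring, so the data give no direction for this change. The chain step (a 3.0-fold lower number from compound 1 to compound 2 (0.47 log units; beyond the scatter)) is a different kind of change and offers only a rough idea of size. In this assay no step beyond the scatter is therefore expected (a 1.2-fold lower number from compound 2 to compound 3 (0.08 log units; within the scatter)), though a wide margin is needed either way. Compound 3 is estimated at 2000 nM (expected range 800 nM to 5000 nM).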

Compound 3, half-maximal inhibitory concentration: 16000 nM
The estimate for compound 3 lay 8.0-fold (0.90 log units) below the measured number, outside the stated range (above it).
By their numbers in this assay, from the lowest: compound 2; then compound 1; then compound 3.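

The ring that stayed unchanged in compounds 1 and 2 now has a measured change, and in this assay it points towards weaker activity (a 6.7-fold higher number from compound 2 to compound 3 (0.82 log units; beyond the scatter)). The step is beyond the usual scatter, even though only one heavy atom enters, a chloro ortho to a large group, so this place on the ring is not indifferent to substitution, at least for this one group on this chain. Nothing given here explains why this single atom has such an effect.

One compound cannot separate the identity of the group from its place: a fluoro or a methyl at the same position, or a chloro elsewhere on the same ring, would help tell these apart. As far as these compounds go, it also remains open whether the chloro step would be of similar size on the shorter chain of compound 1.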